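The source may report more compounds than this note shows. Statements on the series, on what has been measured and on what is new or still open speak of the compounds shown alone.

Working notes on the series. Compound 1 `O=C(Sc1cccnc1C(=O)O)c1ccc(Cl)cc1` and compound 2 `O=C(Sc1cccnc1C(=O)O)c1ccc(C(F)(F)F)cc1` differ in one place. In a physicochemical assay for pharmacokinetics, at pH 6 (on this read-out higher numbers stand for a longer-lived compound and lower numbers for a shorter-lived compound), compound 1 gives 7.9 h and compound 2 gives 3 h, which leaves compound 2 the lower of the two. Next in line is compound 3 `COc1ccc(C(=O)Sc2cccnc2C(=O)O)cc1`, with this difference: methoxy in place of trifluoromethyl on an aromatic carbon. It is methoxy in place of trifluoromethyl on an aromatic carbon, para to a large group.

For the measured compounds named here, one measured step bears on this: a 2.6-fold lower number from compound 1 to compound 2 (0.42 log units; beyond the scatter), a modest step beyond the scatter, with trifluoromethyl in place of chloro on an aromatic carbon. Trifluoromethyl going out is therefore expected to raise the number in this assay, though this rests on that single step. Going by the values given here, no measured compound carries methoxy, so the size is uncertain. The expected move is larger than that step: a 6.7-fold higher number from compound 2 to compound 3 (0.82 log units; beyond the scatter). For compound 3 the estimate is 20 h, with an expected range of 7 h to 50 h.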

Compound 3, half-life: 43.9 h
For compound 3 the middle estimate is 2.2-fold (0.34 log units) below the measured one, and the stated range covers the measured number.
By their numbers in this assay, from the lowest: compound 2; then compound 1; then compound 3.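

At this place, on an aromatic carbon para to a large group, the change to methoxy in this assay gives a 15-fold higher number from compound 2 to compound 3 (1.17 log units; beyond the scatter) and a 5.6-fold higher number from compound 1 to compound 3 (0.74 log units; beyond the scatter), so the move runs the same way from both earlier groups and lies beyond the scatter each time. The chloro and trifluoromethyl pair showed only a modest spread, whereas methoxy widens the range at this position and leaves compound 3 highest of the three. Nothing at hand explains why the half-life moves in this way.

The compounds shown leave open how an amine, a hydroxyl or a longer chain such as ethoxy would read in the same place. They also leave open whether methoxy would move the number the same way at another carbon of the ring.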